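Cytotoxicity of a boron-bearing series: predicting compound 4

The compounds below may be only part of what the source reports. "The series", "measured", "known", "first", "only" and "open" are said of these compounds alone.

Of the compounds shown here, three sharing one core have been tested in an ADME assay on WI-38 cells (Homo sapiens) for cytotoxicity, read by MTT assay, with a stated time of 72 h; a lower number here means a stronger inhibitor, a higher number a weaker inhibitor. Compound 1 `CCNC(=O)CCc1cccc2c1B(O)OC2`, carrying a short ethylamide tail, reaches only the assay limit of > 100000 nM, so no number is known for it. That reading is the limit of > 100000 nM in this assay, at which 1 of the 3 values shown sits. Compound 2 `COc1ccc(-c2cccc(NC(=O)CCc3cccc4c3B(O)OC4)c2)cc1` gives 1400 nM, the lowest of the two real numbers. Compound 3 `O=C(CCc1cccc2c1B(O)OC2)Nc1cccc(-c2ccc(OC(F)(F)F)cc2)c1` gives 25000 nM. Within the data shown here, the single measured step, an 18-fold higher number from compound 2 to compound 3 (1.25 log units; beyond the scatter), shows that altering the outer ring can shift the number well beyond the scatter. Compound 4 `CC(=O)c1cccc(-c2cccc(NC(=O)CCc3cccc4c3B(O)OC4)c2)c1` differs from compound 2 by 3-acetylphenyl in place of 4-methoxyphenyl on an aromatic carbon. Only an 18-fold higher number from compound 2 to compound 3 (1.25 log units; beyond the scatter) bears on this, so a sizable shift is plausible while its direction stays uncertain. Compound 4 is expected to give about 5000 nM, between 1000 nM and 30000 nM. For compound 4 this means an expected step of a 3.6-fold higher number from compound 2 to compound 4 (0.55 log units; beyond the scatter).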

Compound 4, half-maximal inhibitory concentration: 2200 nM
Estimate against measurement, compound 4: 2.3-fold (0.36 log units) above, and the stated range covers the measured number.
By their numbers in this assay, from the lowest: compounds 2 and 4 (each within the scatter of the next); then compound 3. At a limit, above all of these: compound 1.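

Placing 3-acetylphenyl in place of 4-methoxyphenyl gives a 1.6-fold higher number from compound 2 to compound 4 (0.20 log units; within the scatter), so the outer ring at this position can be exchanged without a readable shift in the number. The large step seen with compound 3 therefore does not hold for every change to this ring. No measurement shown explains why one change moves the number and the other does not.

Still open, as far as these compounds go, is whether an amine or a carboxylic acid on the outer ring would leave the number as close to that of compound 2. From the compounds shown here alone, a longer chain between the amide and the shared core remains equally open.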